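This account rests on a few compounds, and the source may have more. Where it says the series, first, only, none or still open, it means among the compounds named here.

In an ADME assay on RAW264.7 cells (Mus musculus) for cytotoxicity, read by MTT assay, with a stated time of 18 h (a higher number here means that more compound is tolerated, a lower number that less compound is tolerated), compound 1, `C=C1C(=O)OC[C@H]1CCOC(=O)Nc1ccc(Cl)cc1`, gives 9140 nM. Compound 3, `C=C1C(=O)OC[C@@H]1CCOC(=O)Nc1ccc(Cl)cc1`, gives 10300 nM in this assay, and the step amounts to a 1.1-fold higher number from compound 1 to compound 3 (0.05 log units; within the scatter); that the two numbers sit so close together is consistent with the fact that compounds 1 and 3 differ only in the configuration as drawn. Compound 2, `C=C1C(=O)OC[C@@H]1CCOC(=O)Nc1ccc(F)cc1F`, gives 14800 nM in this assay, so all three numbers that have been measured lie within the usual scatter of one another, and compound 1 cannot be set apart from either of the other two.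

The compound that follows is compound 4, `C=C1C(=O)OC[C@H]1CCOC(=O)Nc1ccc(CC)cc1`. Relative to compound 1 the change is ethyl in place of chloro on an aromatic carbon. Among the measured compounds shown here, none of the measured steps touches this part of the molecule: the only step on record, from compound 1 to compound 3, concerns configuration alone, and the pair of compound 1 and compound 2 differs in more than one place, so its two values show only that both lie within the scatter. For the measured compounds named here, there is therefore no measured step that bears on the exchange of chloro for ethyl, and no step beyond the scatter is expected in this assay for compound 4. Compound 4 is estimated to give 10000 nM in this assay, in the range 4500 nM to 22000 nM. This expectation corresponds to a step of a 1.1-fold higher number from compound 1 to compound 4 (0.04 log units; within the scatter).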

Compound 4, half-maximal cytotoxic concentration: 11400 nM
The estimate for compound 4 lay 1.1-fold (0.06 log units) below the measured number; the range from low to high includes it.
By their numbers in this assay, from the lowest: compounds 1, 3, 4 and 2 (each within the scatter of the next).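

In this assay, among the compounds shown here, the exchange on an aromatic carbon of a six-membered aromatic ring of carbon only, para to a large group, amounts to a 1.2-fold higher number from compound 1 to compound 4 (0.10 log units; within the scatter), and this is the first step on record that concerns the group at this position rather than configuration alone. It shows that, in this one pair, replacing chloro with ethyl, a swap of one heavy atom for two carbons with no hydrogen-bond donor or acceptor on either side, does not separate the two compounds in this assay. For the compounds shown here, nothing measured here gives a reason for this result, as the only information at hand concerns a different kind of change.

On these data alone, whether a group of another kind at this same place, such as an amine, a carboxylic acid or a longer chain such as butyl, would give a step beyond the scatter remains open. Also open, as far as these compounds go, is whether ethyl at this position would give a similar number with the stereocentre drawn R, the configuration of compound 3.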